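Series notes: compound 4 from compound 3

The source may hold more compounds than are shown below. What is called first, only, known or untested is meant among the compounds shown, and "the series" means these compounds.

Compound 3 `CCC1(c2ccccc2)CC(=O)C(C2CC(c3ccc(-c4ccc(Br)cc4)cc3)Cc3ccccc32)=C(O)O1` carries the ethyl on the saturated ring carbon of the shared core together with the 4-bromophenyl arm. In a functional assay on A549 cells (Homo sapiens) for inhibition, with a stated time of 72 h (a higher number here means a weaker inhibitor, a lower number a stronger inhibitor), compound 3 reaches only the assay limit, > 10000 nM, so no number is known for it. Compound 1 `CC1(c2ccccc2)CC(=O)C(C2CC(c3ccc(-c4ccc(Br)cc4)cc3)Cc3ccccc32)=C(O)O1` gives 1830 nM in this assay. Compound 2 `CC1(c2ccccc2)CC(=O)C(C2CC(c3ccc(OCc4ccc(C(F)(F)F)cc4)cc3)Cc3ccccc32)=C(O)O1` sits at the limit as well, > 10000 nM. Compound 4 `CCC1(c2ccccc2)CC(=O)C(C2CC(c3ccc(OCc4ccc(C(F)(F)F)cc4)cc3)Cc3ccccc32)=C(O)O1` is compound 3 with (4-(trifluoromethyl)benzyl)oxy in place of 4-bromophenyl on an aromatic carbon. Among the measured compounds shown here, the same exchange has been measured once, as an at least 5.4-fold higher number from compound 1 to compound 2 (0.73 log units; beyond the scatter); the other measured step, an at least 5.4-fold higher number from compound 1 to compound 3 (0.73 log units; beyond the scatter), is the one that carries compound 3 itself onto the limit (the limit of > 10000 nM in this assay, at which 2 of the 3 values shown sit). Both steps run toward weaker inhibition, so compound 4 is expected to lie at or beyond the limit, with an expected step that the limit leaves unreadable from compound 3 to compound 4 in this assay. Compound 4 is therefore estimated at 30000 nM, between 10000 nM and 150000 nM, and is most likely to be reported once more as a limit rather than a number.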

Compound 4, half-maximal inhibitory concentration: > 10000 nM
Compound 4 was reported as a limit (the forecaster's own chance of this, stated with the estimate: 90%); the middle value does not contradict the limit.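

In this assay compound 4 gives only a limit, > 10000 nM, so its steps from compound 2 and from compound 3 cannot be read. The compounds shown leave open how compound 2, compound 3 and compound 4 rank against one another: the limit of > 10000 nM in this assay, at which 3 of the 4 values shown sit.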